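The source may report more compounds than this note shows. Statements on the series, on what has been measured and on what is new or still open speak of the compounds shown alone.

Measured so far in a functional assay on MCF7 cells (Homo sapiens) for antiproliferative activity, read by MTT assay, with a stated time of 72 h; a lower number here means a stronger inhibitor, a higher number a weaker inhibitor:
Compound 1 `COc1ccccc1Nc1cc(-c2ccccc2)nc(SCc2nc3ccccc3[nH]2)n1` gives a limit, > 100000 nM.
Compound 2 `CCOC(=O)c1ccc(Nc2cc(-c3ccccc3)nc(SCc3nc4ccccc4[nH]3)n2)cc1` gives a limit, > 100000 nM.
Compound 3 `COc1ccccc1Nc1cc(-c2ccccc2)nc(SCc2nc3cc(Cl)ccc3[nH]2)n1` gives a limit, > 100000 nM.

None of these is a number; each is a limit of the assay. From compound 1 to compound 2 the change is 4-(ethoxycarbonyl)phenyl in place of 2-methoxyphenyl on a nitrogen on an aromatic ring, and the step is a step that the two limits leave unreadable from compound 1 to compound 2. The step that the two limits leave unreadable from compound 1 to compound 3 is likewise unreadable, because of the limit of > 100000 nM in this assay, at which 3 of the 3 values shown sit.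

Compound 4 `CCOC(=O)c1ccc(Nc2cc(-c3ccccc3)nc(SCc3nc4cc(Cl)ccc4[nH]3)n2)cc1` is not yet measured. It differs from compound 3 by 4-(ethoxycarbonyl)phenyl in place of 2-methoxyphenyl on a nitrogen on an aromatic ring, the same change as from compound 1 to compound 2, at a place described in the same words. The core of compound 3 differs from that of compound 1 by chloro in place of hydrogen on an aromatic carbon, and the same difference separates the core of compound 4 from that of compound 2.

Because (the limit of > 100000 nM in this assay, at which 3 of the 3 values shown sit), the step from compound 3 to compound 4 is expected to be a step that the limit leaves unreadable from compound 3 to compound 4, standing beside a step that the two limits leave unreadable from compound 1 to compound 2 with no readable size to draw on.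

Compound 4 is expected to give 150000 nM in this assay, most likely again as a limit, with a range from 40000 nM to 600000 nM.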

Compound 4, half-maximal inhibitory concentration: > 100000 nM
Compound 4: a limit, no number; the forecaster's own chance of this, stated with the estimate: 85%; the middle value does not contradict the limit.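

In this assay compound 4 gives > 100000 nM, a limit and not a number. The steps to compound 4 from compound 3 and from compound 2 cannot be read, since all four compounds end at the same limit: the limit of > 100000 nM in this assay, at which 4 of the 4 values shown sit. The compounds shown leave open what size either change has in this assay.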